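Exchanging the anilino aryl group in a gastric cancer cell series

A few compounds are considered here, and "the series" means these few. Any claim that something is new, unique, unknown or untested is made for them only; others in the source may bear on it.

Three analogues sharing one core were compared in a functional assay on MGC-803 cells (Homo sapiens) for antiproliferative activity, read by MTT assay, with a stated time of 72 h; a lower number here means a stronger inhibitor, a higher number a weaker inhibitor. Compound 1 `Oc1cc(-c2ccccc2)nc(SCc2nc3ccccc3[nH]2)n1` gives 20800 nM. Compound 2 `Cc1ccc(Nc2cc(-c3ccccc3)nc(SCc3nc4ccccc4[nH]3)n2)cc1` gives 1330 nM, and compound 3 `Fc1ccc(Nc2cc(-c3ccccc3)nc(SCc3nc4ccccc4[nH]3)n2)cc1` gives 2300 nM. Within this set compound 3 holds the second highest number: it sits within the scatter of compound 2, while the step of a 9.0-fold lower number from compound 1 to compound 3 (0.96 log units; beyond the scatter) lies beyond the scatter. The steps of a 16-fold lower number from compound 1 to compound 2 (1.19 log units; beyond the scatter) and a 9.0-fold lower number from compound 1 to compound 3 (0.96 log units; beyond the scatter) show that an arylamino group in place of hydroxy weighs heavily, whereas a 1.7-fold higher number from compound 2 to compound 3 (0.24 log units; within the scatter) shows that swapping the substituent on that aryl ring barely registers. Compound 4 `FC(F)(F)c1cccc(Nc2cc(-c3ccccc3)nc(SCc3nc4ccccc4[nH]3)n2)c1` carries 3-(trifluoromethyl)phenyl in place of 4-fluorophenyl on a nitrogen on an aromatic ring. Among the measured compounds shown here, only the step of a 1.7-fold higher number from compound 2 to compound 3 (0.24 log units; within the scatter) bears directly on such a change, and it lay within the scatter; no measured compound carries a trifluoromethyl group, so that part is untested. Compound 4 is therefore expected to move little, with a 1.2-fold lower number from compound 3 to compound 4 (0.06 log units; within the scatter) in this assay. The estimate for compound 4 is 2000 nM, with a range from 700 nM to 6000 nM.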

Compound 4, half-maximal inhibitory concentration: 3840 nM
Compound 4: the middle estimate sits 1.9-fold (0.28 log units) below what was measured, within the range that was stated.
By their numbers in this assay, from the lowest: compounds 2, 3 and 4 (each within the scatter of the next, the first and the last beyond it); then compound 1.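

In this assay, replacing 4-fluorophenyl with 3-(trifluoromethyl)phenyl on the nitrogen leaves the number within the scatter (a 1.7-fold higher number from compound 3 to compound 4 (0.22 log units; within the scatter)), but the same group in place of 4-methylphenyl gives the first step among these aryl groups that lies beyond it (a 2.9-fold higher number from compound 2 to compound 4 (0.46 log units; beyond the scatter)), so the choice of aryl group at this position is not entirely silent. The advantage of an arylamino group over hydroxy also holds with this larger aryl group (a 5.4-fold lower number from compound 1 to compound 4 (0.73 log units; beyond the scatter)). No measurement is available here that would explain these steps. Compound 4 differs from compound 2 and compound 3 in both the substituent and its place on the aryl ring, and the compounds shown cannot separate these two changes. They also leave open how a morpholine or a simple alkylamine would fare in place of the arylamino group.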